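The source may hold more compounds than are shown below. What is called first, only, known or untested is meant among the compounds shown, and "the series" means these compounds.

Measured in an ADME assay on HEK293 cells (Homo sapiens) for cytotoxicity, read by MTT assay, with a stated time of 48 h; on this read-out higher numbers stand for weaker inhibition and lower numbers for stronger inhibition:

Compound 1 `CCS(=O)(=O)Nc1ccc(NC(=O)c2cccc(C(F)(F)F)c2)cc1C`: 210000 nM
Compound 2 `Cc1cc(NC(=O)c2cccc(C(F)(F)F)c2)ccc1NS(=O)(=O)C(F)(F)F`: 131000 nM
Compound 3 `CCS(=O)(=O)Nc1ccc(NC(=O)c2cccc(C(F)(F)F)c2)cc1OC`: > 250000 nM

The value for compound 3 is a limit of this assay, not a number, (the limit of > 250000 nM in this assay, at which 1 of the 3 values shown sits). Compound 4 `COc1cc(NC(=O)c2cccc(C(F)(F)F)c2)ccc1NS(=O)(=O)C(F)(F)F` awaits measurement in this assay.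

Compound 4 differs from compound 3 by trifluoromethyl in place of ethyl on a sulfonyl sulfur. This is the same change as from compound 1 to compound 2, (trifluoromethyl in place of ethyl on a sulfonyl sulfur), with the two place descriptions agreeing word for word; that step was a 1.6-fold lower number from compound 1 to compound 2 (0.20 log units; within the scatter). The two cores differ in methoxy in place of methyl on an aromatic carbon, and that step was an at least 1.1-fold higher number from compound 1 to compound 3 (0.07 log units; that floor lies within the scatter). Both steps lie within the scatter.

For compound 4 the expected step in this assay is an at least 1.1-fold lower number from compound 3 to compound 4 (0.05 log units; that floor lies within the scatter). This expectation rests on a 1.6-fold lower number from compound 1 to compound 2 (0.20 log units; within the scatter). Since compound 3 sits at a limit, compound 4 may again return only a limit. Compound 4 is estimated at 220000 nM, with a range from 100000 nM to 600000 nM.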

Compound 4, half-maximal inhibitory concentration: > 250000 nM
Compound 4 was reported as a limit (the forecaster's own chance of this, stated with the estimate: 60%); at least 1.1-fold (0.05 log units) between middle value and limit.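

In this assay, the step from ethyl to trifluoromethyl on the sulfonyl sulfur cannot be read on the core of compound 3, because compound 3 and compound 4 are both limits of the assay: the limit of > 250000 nM in this assay, at which 2 of the 4 values shown sit.

Methoxy in place of methyl with trifluoromethyl on the sulfonyl sulfur gives an at least 1.9-fold higher number from compound 2 to compound 4 (0.28 log units; that floor lies within the scatter) and, set beside the same change with ethyl on the sulfonyl sulfur: the same change on two cores in this assay, an at least 1.1-fold higher number (0.07 log units; that floor lies within the scatter) from compound 1 to compound 3 and an at least 1.9-fold higher number (0.28 log units; that floor lies within the scatter) from compound 2 to compound 4; the limit leaves it open whether they differ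

The compounds are thus compatible with either change carrying from one core to the other, but they do not show that it carries at the same size.

Still open, on these data alone, is how a longer chain on the sulfonyl sulfur would read in this assay. Also open, as far as these compounds go, is the effect of an amine or a carboxylic acid in place of methyl or methoxy on the aromatic carbon.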